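A few compounds are considered here, and "the series" means these few. Any claim that something is new, unique, unknown or untested is made for them only; others in the source may bear on it.

Of the compounds shown here, three sharing one core have been tested in a functional assay on cells (Lymphocyte, Homo sapiens), read by trypan blue exclusion, with a stated time of 16 h, tested at 2.5 uM; a lower number here means a weaker effect, a higher number a stronger effect of the compound at the concentration tested. Compound 1 `CCCCCCCCCCCCCCCCc1c(C)c(N(C)C)nc(C)c1O` gives 84%. Compound 2 `CCCCCCCCCCc1c(C)c(N(C)C)nc(C)c1O`, which carries a shorter chain, gives 86%, and compound 3 `CCCCCCCCCCCCCCCCc1nc(N2CCC2)c(C)c(C)c1O`, which carries an azetidin-1-yl group on a different carbon of the core, gives 87%. On these numbers compound 1 stands lowest of the three, though both companions sit within the usual scatter of it. For the measured compounds named here, the single measured step, a number 2 percentage points higher from compound 1 to compound 2 (within the scatter), concerns only the chain and leaves the nitrogen-bearing group untouched.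

Compound 4 `CCCCCCCCCCCCCCCCc1c(C)c(N2CCC2)nc(C)c1O` has not yet been measured. It differs from compound 1 in one place: azetidin-1-yl in place of dimethylamino on an aromatic carbon. Going by the values given here, no measured step swaps dimethylamino for azetidin-1-yl on the same carbon, so the only guide is that compound 3, which also carries azetidin-1-yl, shows a number that differs from that of compound 1 by less than the scatter. A step of no size beyond the scatter is therefore expected in this assay, a number 2 percentage points higher from compound 1 to compound 4 (within the scatter). Compound 4 is estimated at 86%, with a range from 78% to 93%.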

Compound 4, a percentage reported as activity, at one concentration (the size of the read-out at that concentration, not a potency): 92%
Compound 4: the middle estimate sits 6 percentage points below what was measured, and the stated range covers the measured number.
By their numbers in this assay, from the lowest: compounds 1, 2, 3 and 4 (each within the scatter of the next).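

In this assay, the swap of dimethylamino for azetidin-1-yl on the aromatic carbon next to the ring nitrogen and para to the hydroxy group can now be read directly, as a number 8 percentage points higher from compound 1 to compound 4 (within the scatter). Compound 3 could not show this, since its azetidin-1-yl group sits on a different carbon of the core, whereas here an open group gives way to a four-membered ring on the same carbon and the read-out stays within the usual scatter at the one concentration tested. No measurement is available that would explain this result.

From the compounds shown here alone, whether larger rings such as pyrrolidin-1-yl or piperidin-1-yl, or a simple primary amine, would behave alike on this carbon remains open. So does whether azetidin-1-yl gives a similar result when paired with the shorter chain of compound 2.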